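Replacing the Trimethoxyphenyl Tail with a Benzothiophene

The compounds below may be only part of what the source reports. "The series", "measured", "known", "first", "only" and "open" are said of these compounds alone.

Compound 1 `COc1ccc(OC)c(CCC(=O)N2CCN(c3ccc(C(F)(F)F)cc3[C@@H](N)CC(C)C)CC2)c1`: 2500 nM
Compound 2 `COc1cc(OC)c(OC)cc1CCC(=O)N1CCN(c2ccc(C(F)(F)F)cc2[C@@H](N)CC(C)C)CC1`: 6100 nM

Both compounds were tested in an assay on HEK293 cells for displacement of a labelled ligand from Melanocortin receptor 4 (Homo sapiens); on this read-out higher numbers stand for weaker inhibition and lower numbers for stronger inhibition. Compound 2 gives the higher of the two numbers, and the gap to compound 1 is beyond the usual scatter: a 2.4-fold higher number from compound 1 to compound 2 (0.39 log units; beyond the scatter).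

Compound 3 `CC(C)C[C@H](N)c1cc(C(F)(F)F)ccc1N1CCN(C(=O)CCc2csc3ccccc23)CC1` differs from compound 2 by 1-benzothiophen-3-yl in place of 2,4,5-trimethoxyphenyl on a saturated chain carbon, two bonds along the chain from a carbonyl carbon. The whole aromatic tail on the chain is exchanged. For the measured compounds named here, only one measured step exists, and it concerns an added methoxy on that tail rather than an exchange of the tail itself, so it bears on the change only loosely. It shows that the numbers on this tail can move by a modest amount, but gives no direction for a change of this size. The expectation for compound 3 is therefore wide: a number near that of compound 2 is expected, with a step of a 1.7-fold lower number from compound 2 to compound 3 (0.24 log units; within the scatter), and the estimate is 3500 nM within a range from 600 nM to 20000 nM.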

Compound 3, inhibition constant: 2300 nM
Compound 3: middle estimate off by 1.5-fold (0.18 log units), on the high side, within the range that was stated.
By their numbers in this assay, from the lowest: compounds 3 and 1 (each within the scatter of the next); then compound 2.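

In this assay, the whole aromatic tail on the saturated chain carbon, two bonds along the chain from a carbonyl carbon, can be exchanged without a loss: 1-benzothiophen-3-yl in place of 2,4,5-trimethoxyphenyl gives a 2.7-fold lower number from compound 2 to compound 3 (0.42 log units; beyond the scatter) and so goes past the scatter. Set against the 2,5-dimethoxyphenyl tail, the same group gives a 1.1-fold lower number from compound 1 to compound 3 (0.04 log units; within the scatter) and stays within the scatter, which shows that, among these three compounds, a tail without any methoxy group can match the better of the two methoxy tails. No measurement here gives a reason for either step.

The compounds shown leave open how 1-benzothiophen-2-yl, an unsubstituted phenyl or an indol-3-yl group would score at this place. They also leave open whether a longer chain leading to the carbonyl would move the number.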